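The source may hold more compounds than are shown below. What is called first, only, known or untested is meant among the compounds shown, and "the series" means these compounds.

Among the compounds with values here, compound 2 `O=C(Nc1nc(-c2cccc(C(F)(F)F)c2)cs1)c1ccc([N+](=O)[O-])o1` gives the lowest of the two numbers so far in an ADME assay on Vero cells (Chlorocebus sabaeus) for cytotoxicity, read by MTT assay, with a stated time of 72 h; a lower number here means a stronger inhibitor, a higher number a weaker inhibitor: compound 2 gives 23900 nM, while compound 1 `O=C(Nc1nc(-c2cccc(F)c2)cs1)c1ccc([N+](=O)[O-])o1` gives 51600 nM. Within the data shown here, the one step between them, a 2.2-fold lower number from compound 1 to compound 2 (0.33 log units; beyond the scatter), is modest. Compound 3 `O=C(Nc1nc(-c2cccc(OC3CCCC3)c2)cs1)c1ccc([N+](=O)[O-])o1` differs from compound 2 by cyclopentyloxy in place of trifluoromethyl on an aromatic carbon. Among the measured compounds shown here, no measured step involves a cyclopentyloxy group, so only the single modest step from compound 1 to compound 2 bears on the change at this position. On that basis a modest step in this assay, downward or none beyond the scatter, is expected for compound 3, namely a 1.3-fold lower number from compound 2 to compound 3 (0.12 log units; within the scatter). Compound 3 is therefore estimated at 18000 nM, in the range 7000 nM to 50000 nM.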

Compound 3, half-maximal inhibitory concentration: 81100 nM
Estimate against measurement, compound 3: 4.5-fold (0.65 log units) below; the measured number lies above the stated range.
By their numbers in this assay, from the lowest: compound 2; then compounds 1 and 3 (each within the scatter of the next).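

In this assay this place on the aromatic ring now shows a rise as well as a fall: cyclopentyloxy in place of trifluoromethyl gives a 3.4-fold higher number from compound 2 to compound 3 (0.53 log units; beyond the scatter) and so runs against the earlier step. Cyclopentyloxy in place of fluoro gives a 1.6-fold higher number from compound 1 to compound 3 (0.20 log units; within the scatter) and leaves trifluoromethyl as the only one of the three groups set apart from the other two. No measurement shown here accounts for this difference. The compounds shown leave open how a methoxy group, an amine or a carboxylic acid at this place would read in this assay and whether the carbon ring of cyclopentyloxy matters more than its oxygen.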